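The source may hold more compounds than are shown below. What is called first, only, known or untested is meant among the compounds shown, and "the series" means these compounds.

Compound 1 `O=C(Nc1cccc(/C=C/C(=O)c2nc3ccccc3[nH]2)c1)c1cccc(Cl)c1`: 1120 nM
Compound 2 `Cc1ccccc1C(=O)Nc1cccc(/C=C/C(=O)c2nc3ccccc3[nH]2)c1`: 1870 nM

For the measured compounds named here, in a functional assay on HCT-116 cells (Homo sapiens) for antiproliferative activity, read by MTT assay, with a stated time of 48 h (on this read-out lower numbers stand for stronger inhibition and higher numbers for weaker inhibition), compound 2 gives 1870 nM, and the only step so far, a 1.7-fold higher number from compound 1 to compound 2 (0.22 log units; within the scatter), lies within the scatter, so the two numbers cannot be told apart. Compound 3 `COc1cccc(C(=O)Nc2cccc(/C=C/C(=O)c3nc4ccccc4[nH]3)c2)c1` carries 3-methoxyphenyl in place of 2-methylphenyl on a carbonyl carbon, on a carbonyl carbon whose other neighbour is an amide-type nitrogen. Going by the values given here, the one step that bears on it swaps a group at that same place and was a 1.7-fold higher number from compound 1 to compound 2 (0.22 log units; within the scatter), so for compound 3 no change beyond the scatter in this assay is expected, a 1.2-fold lower number from compound 2 to compound 3 (0.10 log units; within the scatter). Compound 3 is therefore estimated at 1500 nM, within 600 nM to 4000 nM.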

Compound 3, half-maximal inhibitory concentration: 3680 nM
The estimate for compound 3 lay 2.5-fold (0.39 log units) below the measured number; measured number inside the range.
By their numbers in this assay, from the lowest: compounds 1, 2 and 3 (each within the scatter of the next, the first and the last beyond it).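

In this assay, replacing 2-methylphenyl with 3-methoxyphenyl on the carbonyl carbon gives a 2.0-fold higher number from compound 2 to compound 3 (0.29 log units; within the scatter), so this change still cannot be told from noise. Methoxy in place of chloro on an aromatic carbon gives a 3.3-fold higher number from compound 1 to compound 3 (0.52 log units; beyond the scatter), the first step in this series to clear the scatter, though only modestly. No supporting measurement is available to explain this difference. Still open, from the compounds shown here alone, is how an amine or a carboxylic acid in place of the chloro or methoxy would read out.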